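Swapping a methylphenyl ester for a pyridyl ester

A few compounds are considered here, and "the series" means these few. Any claim that something is new, unique, unknown or untested is made for them only; others in the source may bear on it.

Measured so far:
compound 1, `C=CCc1ccc(OC(=O)C2CCCCC2)c(OC)c1`, 3.52
compound 2, `C=CCc1ccc(OC(=O)c2ccc(C)cc2)c(OC)c1`, 2.87
compound 3, `C=CCc1ccc(OC(=O)c2ccccc2C)c(OC)c1`, 2.87

All three share one core and differ only in the group attached to the carbonyl carbon of the ester. In a physicochemical assay for lipophilicity (on this read-out higher numbers stand for higher lipophilicity and lower numbers for lower lipophilicity), compound 1 gives 3.52, the highest of the three numbers. The two aromatic esters sit lower: a number 0.65 log units lower from compound 1 to compound 2 (beyond the scatter) and a number 0.65 log units lower from compound 1 to compound 3 (beyond the scatter), while no change at the digits printed from compound 2 to compound 3 (within the scatter), so compound 2 and compound 3 stand level with each other at the bottom of the set.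

Compound 4, `C=CCc1ccc(OC(=O)c2cccnc2)c(OC)c1`, has not yet been measured. Its change from compound 2 is pyridin-3-yl in place of 4-methylphenyl on a carbonyl carbon. For the measured compounds named here, none of the measured steps covers this kind of change: the steps seen so far exchange a saturated ring for an aromatic one, or move a methyl around an aromatic ring, and none brings in a ring hetero atom or a hydrogen-bond acceptor. The expectation therefore rests on the counted difference alone. Because the 4-methylphenyl of compound 2 at 2.87 gives way to a smaller ring that carries one hydrogen-bond acceptor, a clearly lower number in this assay is expected, larger than any step seen here. The expected step is a number 1.32 log units lower from compound 2 to compound 4 (beyond the scatter). For compound 4 the estimate is 1.55, with a range from 1.05 to 2.05.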

Compound 4, partition coefficient: 0.86
Compound 4: the middle estimate sits 0.69 log units above what was measured, outside the stated range (below it).
By their numbers in this assay, from the lowest: compound 4; then compounds 2 and 3 (each within the scatter of the next); then compound 1.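

In this assay, for the compounds shown here, this place on the carbonyl carbon proves far more sensitive to a ring hetero atom than the earlier compounds could show: pyridin-3-yl gives a number 2.01 log units lower from compound 2 to compound 4 (beyond the scatter) and, against the other methylphenyl ester, a number 2.01 log units lower from compound 3 to compound 4 (beyond the scatter). Against the saturated ring the same group gives a number 2.66 log units lower from compound 1 to compound 4 (beyond the scatter) and thereby stretches the range at this one place well beyond what the cyclohexyl and methylphenyl esters showed on their own. The change swaps a carbon-only ring with its methyl for a smaller ring holding one nitrogen and one hydrogen-bond acceptor, yet no measurement here accounts for the size of the step.

The compounds shown leave open how much of the step belongs to the nitrogen and how much to the lost methyl, which a plain phenyl ester would help to separate, and whether the place of the nitrogen in the ring matters, as pyridin-2-yl and pyridin-4-yl esters would show. On these data alone, how far an amine or a carboxylic acid on the aromatic ring would shift the number at this same place also stays open.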